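Hydroxy in Place of Methyl on the Side Chain

This account rests on a few compounds, and the source may have more. Where it says the series, first, only, none or still open, it means among the compounds named here.

In a functional assay on HEL cells (Homo sapiens) for cytotoxicity (on this read-out lower numbers stand for higher toxicity in this test and higher numbers for lower toxicity in this test), compound 1, `CCCOCN1c2ccccc2C(=O)NS1(=O)=O`, gives > 50 ug/mL; this value is a limit of the test rather than a measured number. Compound 2, `CC(=O)OCCOCN1C(=O)c2ccccc2NS1(=O)=O`, also reaches only a limit in this assay, at > 50 ug/mL. Among the measured compounds shown here, compound 3, `O=C(OCCOCN1c2ccccc2C(=O)N(Cc2ccccc2)S1(=O)=O)c1ccccc1`, is the one compound with a number, giving 50 ug/mL in this assay. Compound 1 thus stands at the limit of > 50 ug/mL in this assay, at which 2 of the 3 values shown sit.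

The unmeasured compound 4, `O=C1NS(=O)(=O)N(COCCO)c2ccccc21`, differs from compound 1 in one place: hydroxy in place of methyl on a saturated chain carbon, two bonds along the chain from an oxygen on a saturated carbon. For the measured compounds named here, no step between measured compounds is at hand to show what such a change does to cytotoxicity; the three compounds share one core and none shows toxicity below the limit of the test. A step that the limit leaves unreadable from compound 1 to compound 4 is expected, which means no movement beyond the usual scatter in either direction. Compound 4 is therefore estimated at 55 ug/mL, within 40 ug/mL and 80 ug/mL, and is most likely to be reported again only as a limit.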

Compound 4, minimum cytotoxic concentration: > 50 ug/mL
Compound 4: only a limit was reported (the forecaster's own chance of this, stated with the estimate: 75%); the middle value lies beyond the limit too.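

Compound 1 and compound 4 each reach only a limit of the test, so no step between them can be read: the limit of > 50 ug/mL in this assay, at which 3 of the 4 values shown sit.

The compounds shown leave open whether hydroxy in place of methyl changes the result in this assay at all, and in which direction.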